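The compounds below may be only part of what the source reports. "The series", "measured", "known", "first", "only" and "open" are said of these compounds alone.

In a functional assay on Ramos cells (Homo sapiens) for antiproliferative activity, read by CCK-8 assay, with a stated time of 72 h, tested at 40 uM (on this read-out lower numbers stand for less inhibition and higher numbers for more inhibition at the one concentration tested (going by the name of the read-out)), compound 2 `CCOC(=O)c1sc(-c2cccc(NC(=O)c3ccccc3)c2)nc1Nc1ccc(N2CCN(C)CC2)cc1` gives 77.1%, and two changes made from it each lowered the read-out. Compound 1 `CCOC(=O)c1sc(-c2cccc(NC(=O)c3ccc(F)cc3)c2)nc1Nc1ccc(N2CCN(C)CC2)cc1` carries fluoro in place of hydrogen on an aromatic carbon, and in this assay compound 1 gives 3.53%, a step of a number 73.6 percentage points lower from compound 2 to compound 1 (beyond the scatter). Compound 3 `CN1CCN(c2ccc(Nc3nc(-c4cccc(NC(=O)c5ccccc5)c4)sc3C(=O)O)cc2)CC1` differs from compound 2 by hydrogen in place of ethyl on an oxygen next to a carbonyl group, and in this assay compound 3 gives 26.3%, a step of a number 50.8 percentage points lower from compound 2 to compound 3 (beyond the scatter). Compound 4 `CN1CCN(c2ccc(Nc3nc(-c4cccc(NC(=O)c5cccc(F)c5)c4)sc3C(=O)O)cc2)CC1` differs from compound 3 by fluoro in place of hydrogen on an aromatic carbon; this is the same kind of change as from compound 2 to compound 1, but the fluoro stands meta to a large group in compound 4 and para to a large group in compound 1. From compound 3 to compound 4 the step is expected to be a number 18.3 percentage points lower from compound 3 to compound 4 (beyond the scatter). Within the data shown here, this expectation rests on the one earlier fluoro step a number 73.6 percentage points lower from compound 2 to compound 1 (beyond the scatter) and on the low starting value of compound 3, 26.3%, which leaves little room to fall. Compound 4 is estimated at 8%.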

Compound 4, a percentage reported as inhibition, at one concentration (the size of the read-out at that concentration, not a potency): 82.7%
For compound 4 the middle estimate is 74.7 percentage points below the measured one, outside the stated range (above it).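

In this assay the fluoro change, made on the core that carries the free carboxylic acid, gives a step of a number 56.4 percentage points higher from compound 3 to compound 4 (beyond the scatter). Set beside the earlier step, this shows that the change cannot be carried from one core to the other in this series, in size or in direction: the same change on two cores in this assay, a number 73.6 percentage points lower (beyond the scatter) from compound 2 to compound 1 and a number 56.4 percentage points higher (beyond the scatter) from compound 3 to compound 4, 130 percentage points apart, beyond the scatter of two such steps. It does not show which difference matters, as the fluoro stands at a different place on the ring in compound 4 than in compound 1 and the cores differ too, and two pairs cannot separate these.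

Left open is how a 3-fluorophenyl behaves on the core bearing the ethyl ester, and how the fluoro placement of compound 1 behaves on the carboxylic acid core. Also open, going by these compounds, is whether chloro or methoxy in place of the fluoro would follow the same course.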